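Replacing 3-(trifluoromethyl)phenyl with 4-hydroxyphenyl in compound 3

The compounds below may be only part of what the source reports. "The series", "measured", "known", "first", "only" and "open" are said of these compounds alone.

Measured in a functional assay on T47D cells (Homo sapiens) for inhibition, read by CCK-8 assay, with a stated time of 72 h, tested at 1 uM; on this read-out lower numbers stand for less inhibition of growth and higher numbers for more inhibition of growth at the one concentration tested:
Compound 1 `CN(C)C(=O)c1cc2cnc(Nc3ccc(NC(=O)C4(C(=O)Nc5cccc(Cl)c5)CC4)cc3)nc2n1C1CCCC1`: 39.3%
Compound 2 `CN(C)C(=O)c1cc2cnc(Nc3ccc(NC(=O)C4(C(=O)Nc5ccc(Cl)c(C(F)(F)F)c5)CC4)cc3)nc2n1C1CCCC1`: 6.9%
Compound 3 `CN(C)C(=O)c1cc2cnc(Nc3ccc(NC(=O)C4(C(=O)Nc5cccc(C(F)(F)F)c5)CC4)cc3)nc2n1C1CCCC1`: 9.7%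

Compound 3 gives 9.7% and belongs to the low pair. Its nearest neighbour is separated by a number 2.8 percentage points higher from compound 2 to compound 3 (within the scatter), its furthest by a number 29.6 percentage points lower from compound 1 to compound 3 (beyond the scatter). Compound 4 `CN(C)C(=O)c1cc2cnc(Nc3ccc(NC(=O)C4(C(=O)Nc5ccc(O)cc5)CC4)cc3)nc2n1C1CCCC1` carries 4-hydroxyphenyl in place of 3-(trifluoromethyl)phenyl on an amide-type nitrogen. Going by the values given here, no measured step makes this exchange. The closest evidence is that both trifluoromethyl compounds sit low, with a number 32.4 percentage points lower from compound 1 to compound 2 (beyond the scatter) alongside the step already given, so compound 1 shows that a ring without trifluoromethyl can stand higher. On these data alone, a hydroxy group remains untested here, so only a modest rise is expected, a number 12.3 percentage points higher from compound 3 to compound 4 (beyond the scatter). The estimate for compound 4 is 22%, within an expected range of 6% to 42%.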

Compound 4, percent growth inhibition at one concentration: 91.5%
Compound 4: middle estimate off by 69.5 percentage points, on the low side, outside the stated range (above it).
By their numbers in this assay, from the lowest: compounds 2 and 3 (each within the scatter of the next); then compound 1; then compound 4.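

In this assay, going by these compounds alone, the ring on the amide-type nitrogen proves able to give far more growth inhibition than the earlier compounds showed, with 4-hydroxyphenyl well above both trifluoromethyl-bearing rings (a number 81.8 percentage points higher from compound 3 to compound 4 (beyond the scatter)) and (a number 84.6 percentage points higher from compound 2 to compound 4 (beyond the scatter)). The exchange also clearly exceeds 3-chlorophenyl, the highest of the earlier rings (a number 52.2 percentage points higher from compound 1 to compound 4 (beyond the scatter)), so the earlier range did not mark the limit at this position. No evidence at hand accounts for this rise. On these data alone, whether a methoxy group or an amine in place of the hydroxy group would hold this level remains open, as does the result for plain phenyl.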